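The source may report more compounds than this note shows. Statements on the series, on what has been measured and on what is new or still open speak of the compounds shown alone.

Measured so far in an assay on membranes from brain with Neuronal acetylcholine receptor; alpha4/beta2 (Rattus norvegicus) as the target; on this read-out higher numbers stand for weaker inhibition and lower numbers for stronger inhibition:
compound 1, `Fc1ccc(-c2cc(OC[C@@H]3CCCN3)cnc2Cl)cn1`, gives 0.0179 nM;
compound 2, `Clc1ncc(OC[C@@H]2CCCN2)cc1-c1ccc(Br)nc1`, gives 0.0195 nM;
compound 3, `Fc1cc(-c2cc(OC[C@@H]3CCN3)cnc2Cl)ccn1`, gives 0.0048 nM.

Compound 4, `Clc1ncc(OC[C@@H]2CCN2)cc1-c1ccnc(Br)c1`, has not yet been measured in this assay. It is related to compound 3 by one change: bromo in place of fluoro on an aromatic carbon. The same kind of change links compound 1 to compound 2: bromo in place of fluoro on an aromatic carbon. The two places are not the same: in the first the site is para to a large group, in the second meta to a large group, so the changes are of the same kind, not the same. How the core of compound 1 and the core of compound 3 differ is not broken down here. The measured step, a 1.1-fold higher number from compound 1 to compound 2 (0.04 log units; within the scatter), lies within the scatter. A similarly small step is expected here, a 1.1-fold higher number from compound 3 to compound 4 (0.06 log units; within the scatter), because the earlier step of a 1.1-fold higher number from compound 1 to compound 2 (0.04 log units; within the scatter) was within the scatter. Compound 4 is therefore estimated at 0.0055 nM, between 0.0025 nM and 0.012 nM.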

Compound 4, inhibition constant: 0.0033 nM
Estimate against measurement, compound 4: 1.7-fold (0.22 log units) above; low and high end bracket the measured number.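

In this assay, putting bromo in place of fluoro gives a 1.5-fold lower number from compound 3 to compound 4 (0.16 log units; within the scatter), so on this core the swap makes no readable difference. The swap behaves alike on both cores, and the two steps cannot be told apart: the same change on two cores in this assay, a 1.1-fold higher number (0.04 log units; within the scatter) from compound 1 to compound 2 and a 1.5-fold lower number (0.16 log units; within the scatter) from compound 3 to compound 4, 1.6-fold (0.20 log units) apart, within the scatter of two such steps

This does not show that the change carries over in general, since it rests on just two pairs, with the halogen at a different place in each pair, and both steps are too small to reveal any real effect of the swap.

Going by these compounds, it stays open whether a group other than these two halogens, such as a methyl, a methoxy group or a nitrile, would also leave the number unchanged at this place. The compounds shown also do not separate the difference between the two cores from the place of the halogen.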